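From Carbonyl to Hydroxy: What to Expect

The source may hold more compounds than are shown below. What is called first, only, known or untested is meant among the compounds shown, and "the series" means these compounds.

In an ADME assay on L02 cells (Homo sapiens) for cytotoxicity, read by MTT assay, with a stated time of 48 h (a higher number here means a weaker inhibitor, a lower number a stronger inhibitor), compound 1 `CCN(CC)CCNC(=O)c1ccc(C(CC)(CC)c2ccc(OCC(=O)C(C)(C)C)c(C)c2)n1CC` gives 2500 nM and compound 2 `CCN(CC)CCCNC(=O)c1ccc(C(CC)(CC)c2ccc(OCC(=O)C(C)(C)C)c(C)c2)n1CC` gives 2300 nM so the two stand level within the scatter, and compound 1 has no clear rank. Compound 3 `CCN(CC)CCNC(=O)c1ccc(C(CC)(CC)c2ccc(OCC(O)C(C)(C)C)c(C)c2)n1CC` is still unmeasured. It carries 1-hydroxy-2,2-dimethylpropyl in place of (tert-butyl)carbonyl on a saturated chain carbon bound to an oxygen on an aromatic ring. Among the measured compounds shown here, the only measured step (a 1.1-fold lower number from compound 1 to compound 2 (0.04 log units; within the scatter)) puts (diethylamino)methyl in place of diethylamino at a different place in the molecule, so it offers only weak guidance on this change. No measurement tests this place directly, and no shift beyond the scatter is expected in this assay on present evidence. The expected step is small (a 1.1-fold higher number from compound 1 to compound 3 (0.05 log units; within the scatter)). For compound 3 the estimated value is 2800 nM with an expected range from 1300 nM to 6000 nM at this early stage.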

Compound 3, half-maximal inhibitory concentration: 2500 nM
Compound 3: the middle estimate sits 1.1-fold (0.05 log units) above what was measured, within the range that was stated.
By their numbers in this assay, from the lowest: compounds 2, 1 and 3 (each within the scatter of the next).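

Putting 1-hydroxy-2,2-dimethylpropyl in place of (tert-butyl)carbonyl, on a saturated chain carbon bound to an oxygen on an aromatic ring, produces no change at the digits printed from compound 1 to compound 3 (within the scatter) in this assay. This is the only direct test shown at this place, and it indicates that exchanging the carbonyl for a hydroxy group, which adds a hydrogen-bond donor and removes a double bond, leaves the cytotoxicity reading level within the scatter. Nothing available explains why the reading stays level.

Still open, from the compounds shown here alone, is whether a quite different group at this place, such as a carboxylic acid or an amine in place of the (tert-butyl)carbonyl, would also leave the reading level. Also open, going by these compounds, is whether the same exchange made on compound 2, with its longer amide side chain, would give a similarly small step.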